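Swapping a Butyl Chain for a Fluorophenyl Ring

A few compounds are considered here, and "the series" means these few. Any claim that something is new, unique, unknown or untested is made for them only; others in the source may bear on it.

Compound 1, `CCCOc1ccc(C(=O)Nc2cccc(Br)n2)cc1`, in an in vitro assay on HEK-tsA201 cells for antagonist activity at Neuronal acetylcholine receptor; alpha3/beta4 (Homo sapiens), read by fluorescence and calcium flux (a higher number here means a weaker inhibitor, a lower number a stronger inhibitor), gives > 100000 nM, which is a limit of the assay and not a number.
Compound 2, `CCCCNc1cccc(NC(=O)c2ccc(OCCC)cc2)n1`, in this assay gives 77800 nM.

Going by the values given here, compound 2 is the only compound here with an actual number in this assay; the weak inhibition it shows is the sole fixed point. The other entry is the limit of > 100000 nM in this assay, at which 1 of the 2 values shown sits. Among the compounds with values here, the single measured step, an at least 1.2-fold lower number from compound 1 to compound 2 (0.10 log units; that floor lies within the scatter), arises from butylamino in place of bromo on an aromatic carbon and stays within the scatter of repeated measurements, so it settles nothing on its own.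

Compound 3, `CCCOc1ccc(C(=O)Nc2cccc(Nc3cccc(F)c3)n2)cc1`, has not yet been measured. It differs from compound 2 by 3-fluorophenyl in place of butyl on a nitrogen on an aromatic ring. Within the data shown here, no measured step covers a change of this kind, so the data give no direction for the new number. The expected step is therefore a 1.3-fold lower number from compound 2 to compound 3 (0.11 log units; within the scatter), meaning no change that would stand out from the scatter, with wide uncertainty around it. Compound 3 is estimated at 60000 nM in this assay, with a range from 20000 nM to 180000 nM, and a fair chance remains that only a limit is reported.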

Compound 3, half-maximal inhibitory concentration: > 100000 nM
Compound 3 was reported as a limit; the forecaster's own chance of this, stated with the estimate: 35%; at least 1.6-fold (0.22 log units) between middle value and limit.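

Placing 3-fluorophenyl on this nitrogen in place of butyl gives an at least 1.2-fold higher number from compound 2 to compound 3 (0.10 log units; that floor lies within the scatter), so in this assay an aromatic ring at this position brings no gain over the butyl chain that stands out from repeated measurements. The step from compound 1 to compound 3 cannot be read, as both values are limits of the assay and not numbers. This leaves compound 2 as the only compound with an actual number, and a single fixed point cannot show a trend at this position, only that the readings crowd against the top of the range: the limit of > 100000 nM in this assay, at which 2 of the 3 values shown sit.

Going by these compounds, how far beyond its limit the true value of compound 3 lies remains open, and with it the real size of the change from butyl to 3-fluorophenyl. Also open, on these data alone, is whether a longer chain such as hexyl, a benzyl group or an unsubstituted phenyl ring on the same nitrogen would give a number that differs from that of compound 2 by more than the scatter.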